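The source may report more compounds than this note shows. Statements on the series, on what has been measured and on what is new or still open speak of the compounds shown alone.

Three compounds share one core and differ only in the group on an amine nitrogen in a ring. In a functional assay on Chem-1 cells for antagonist activity at C-X-C chemokine receptor type 4 (Homo sapiens), read by calcium flux (on this read-out lower numbers stand for stronger inhibition and higher numbers for weaker inhibition), compound 1 `NCCCCN(C[C@H]1CN(C(=O)OCc2ccccc2)CCN1)[C@H]1CCCc2cccnc21` gives 18 nM, compound 2 `NCCCCN(C[C@H]1CN(S(=O)(=O)c2ccc3ccccc3c2)CCN1)[C@H]1CCCc2cccnc21` gives 71 nM, and compound 3 `NCCCCN(C[C@H]1CN(S(=O)(=O)c2ccc(Cl)cc2)CCN1)[C@H]1CCCc2cccnc21` gives 2 nM, the lowest of the three. The steps to it were a 9.0-fold lower number from compound 1 to compound 3 (0.95 log units; beyond the scatter) and a 36-fold lower number from compound 2 to compound 3 (1.55 log units; beyond the scatter). Compound 4 `NCCCCN(C[C@H]1CN(C(=O)Nc2ccccc2)CCN1)[C@H]1CCCc2cccnc21` carries phenylcarbamoyl in place of (4-chlorophenyl)sulfonyl on an amine nitrogen in a ring. For the measured compounds named here, no measured step covers this exact exchange; the nearer comparison is compound 1, whose benzyloxycarbonyl group gave 18 nM, so a higher number than compound 3 is expected. The expected step is a 7.5-fold higher number from compound 3 to compound 4 (0.88 log units; beyond the scatter). Compound 4 is estimated at 15 nM, most likely between 4 nM and 60 nM.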

Compound 4, half-maximal inhibitory concentration: 21000 nM
Estimate against measurement, compound 4: 1400-fold (3.15 log units) below; measured number outside the range, above it.
By their numbers in this assay, from the lowest: compound 3; then compound 1; then compound 2; then compound 4.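

For the compounds shown here, at this ring nitrogen, the choice of group can matter far more than the earlier compounds showed: there is an 11000-fold higher number from compound 3 to compound 4 (4.02 log units; beyond the scatter), and also a 1200-fold higher number from compound 1 to compound 4 (3.07 log units; beyond the scatter). The second step is the sharper one, as exchanging only benzyloxy for anilino on the same carbonyl carbon takes the number far past that of every earlier compound. No available evidence explains this loss. Still open, as far as these compounds go, is whether the amide hydrogen matters, which a methyl group on the anilino nitrogen would test. A benzylamino group on the carbonyl carbon would show whether a longer link to the phenyl ring changes the result.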